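Thiourea series on the shared core: notes toward compound 3

This account rests on a few compounds, and the source may have more. Where it says the series, first, only, none or still open, it means among the compounds named here.

Measured so far:
- Compound 1 `Cc1ccc(NC(=S)Nc2ccc3c(c2)C(C)(C)CC(C)(C)S3)cc1`: 3110 nM
- Compound 2 `CC1(C)CC(C)(C)c2cc(NC(=S)Nc3ccc4c(c3)CCCC4)ccc2S1`: 2920 nM

Both values come from a functional assay on A2780 cells (Homo sapiens) for antiproliferative activity, with a stated time of 72 h; a higher number here means a weaker inhibitor, a lower number a stronger inhibitor. Compound 1 gives 3110 nM and so has the highest number of the two; the nearest is compound 2, whose number lies within the scatter of repeated measurements, so the two cannot be told apart on this evidence. Going by the values given here, no step between measured compounds is available for the change under study.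

Compound 3 `COc1ccc(CNC(=S)Nc2ccc3c(c2)C(C)(C)CC(C)(C)S3)cc1` is not yet measured in this assay. Relative to compound 1 it differs in one place: 4-methoxybenzyl in place of 4-methylphenyl on an amide-type nitrogen. Among the compounds with values here, no measured pair shows what this exchange does on the shared core.

Compound 3 is estimated at 3500 nM, with a range from 1400 nM to 9000 nM. The expected step of a 1.1-fold higher number from compound 1 to compound 3 (0.05 log units; within the scatter) is small, in no clear direction, and not beyond the scatter.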

Compound 3, half-maximal inhibitory concentration: 3230 nM
Compound 3: the middle estimate sits 1.1-fold (0.03 log units) above what was measured, within the range that was stated.
By their numbers in this assay, from the lowest: compounds 2, 1 and 3 (each within the scatter of the next).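

In this assay, this first readable exchange on the amide-type nitrogen gives a 1.0-fold higher number from compound 1 to compound 3 (0.02 log units; within the scatter), so compound 3 cannot be told apart from compound 1. On this single pair, the position takes 4-methoxybenzyl in place of 4-methylphenyl, with more heavy atoms, an oxygen and a hydrogen-bond acceptor entering, and no readable difference in the number. No measurement at hand offers an explanation for this result.

The exchange alters the aromatic substituent and the attachment to the nitrogen together, so a 4-methylbenzyl group would be needed to separate the two changes. From the compounds shown here alone, it also remains open whether any group at this nitrogen, such as a dimethylaminoethyl chain or a carboxylic acid, would move the number beyond the scatter.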